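From 3-Carboxyphenyl to 4-Carboxy-3-chlorophenyl on Compound 3

A few compounds are considered here, and "the series" means these few. Any claim that something is new, unique, unknown or untested is made for them only; others in the source may bear on it.

In an assay on HEK293 cells for positive allosteric modulation of metabotropic glutamate receptor 3 (Rattus norvegicus), read by thallium flux, with a stated time of 2.5 min (on this read-out higher numbers stand for larger maximal responses and lower numbers for smaller maximal responses), compound 3 `Cc1c(OCCCCOc2cccc(C(=O)O)c2)ccc(C(=O)CC2CCCC2)c1C` gives 16.5%, the second highest of three numbers. Compound 2 `Cc1c(OCCCCOc2ccc(C(=O)O)cc2)ccc(C(=O)CC2CCCC2)c1C` gives 12.2%, and the gap a number 4.3 percentage points higher from compound 2 to compound 3 (within the scatter) is within the scatter. Compound 1 `Cc1c(OCCCCOc2ccccc2C(=O)O)ccc(C(=O)CC2CCCC2)c1C` gives 28%, so that a number 11.5 percentage points lower from compound 1 to compound 3 (beyond the scatter) stands beyond it. Compound 4 `Cc1c(OCCCCOc2ccc(C(=O)O)c(Cl)c2)ccc(C(=O)CC2CCCC2)c1C` carries 4-carboxy-3-chlorophenyl in place of 3-carboxyphenyl on an oxygen on a saturated carbon. The only step that bears on it is the move between 4-carboxyphenyl and 3-carboxyphenyl, which was within the scatter; the chlorine has no precedent among these compounds. Compound 4 is therefore expected to show a number 2.5 percentage points lower from compound 3 to compound 4 (within the scatter), a step not beyond the scatter. Compound 4 is estimated at 14%, within 7% to 24%.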

Compound 4, largest response reached (reported as percent of maximum), in percent of the reference or control that the assay uses: 35.5%
Estimate against measurement, compound 4: 21.5 percentage points below; the whole stated range lies below it.
By their numbers in this assay, from the lowest: compounds 2 and 3 (each within the scatter of the next); then compounds 1 and 4 (each within the scatter of the next).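

In this assay, chloro in place of hydrogen on an aromatic carbon gives a number 23.3 percentage points higher from compound 2 to compound 4 (beyond the scatter) and shows that the 4-carboxyphenyl group need not stay at the low end of these numbers. The swap from 3-carboxyphenyl gives a number 19 percentage points higher from compound 3 to compound 4 (beyond the scatter) but changes two things at once, so it cannot be credited to the chlorine alone. With a number 7.5 percentage points higher from compound 1 to compound 4 (within the scatter) there is no order between these two compounds. On these data alone, what chloro does on 2-carboxyphenyl or 3-carboxyphenyl stays open, as does whether fluoro or methyl in its place gives a like step. Nothing given here explains the rise.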